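Swapping Cyclopentyl for tert-Butyl at the Benzylic Carbon

This account rests on a few compounds, and the source may have more. Where it says the series, first, only, none or still open, it means among the compounds named here.

For the measured compounds named here, compound 1 `O=C(O)CCNC(=O)c1ccc(C(Oc2ccc(-n3cc(C(F)(F)F)cn3)cc2)C2CCCC2)cc1` gives 420 nM in an assay on cells for displacement of a labelled ligand from Glucagon receptor (Homo sapiens), in the presence of a further agent that is not named here (a lower number here means a stronger inhibitor, a higher number a weaker inhibitor), the second highest of the three numbers measured so far. Compound 3 `CCCC(Oc1ccc(-n2cc3ccccc3n2)cc1)c1ccc(C(=O)NCCC(=O)O)cc1` gives 290 nM in this assay, a number within the scatter of compound 1, while compound 2 `CCCC(Oc1ccc(-n2cc(C#N)cn2)cc1)c1ccc(C(=O)NCCC(=O)O)cc1` gives 4100 nM. Going by the values given here, the only step seen so far, a 14-fold lower number from compound 2 to compound 3 (1.15 log units; beyond the scatter), alters a different part of the shared core, so it does not bear directly on the present question. Compound 4 `CC(C)(C)C(Oc1ccc(-n2cc(C(F)(F)F)cn2)cc1)c1ccc(C(=O)NCCC(=O)O)cc1` differs from compound 1 in one place: tert-butyl in place of cyclopentyl on a saturated chain carbon bound to an aromatic carbon and an oxygen on an aromatic ring. Among the compounds with values here, no measured pair changes this position, so little guides the expectation. Compound 4 is therefore expected to show a 1.2-fold higher number from compound 1 to compound 4 (0.08 log units; within the scatter), no step beyond the scatter. The estimate for compound 4 is 500 nM, with a range from 200 nM to 1500 nM.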

Compound 4, inhibition constant: 170 nM
Beside the measured number, compound 4's estimate is 2.9-fold (0.47 log units) above it; measured number outside the range, below it.
By their numbers in this assay, from the lowest: compounds 4, 3 and 1 (each within the scatter of the next, the first and the last beyond it); then compound 2.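

The saturated chain carbon bound to an aromatic carbon and an oxygen on an aromatic ring proves sensitive to the group it carries: tert-butyl in place of cyclopentyl gives a 2.5-fold lower number from compound 1 to compound 4 (0.39 log units; beyond the scatter). A modest step, but it shows that the cyclopentyl ring is not needed for inhibition in this pair. Nothing available explains the difference. Going by these compounds, whether losing the ring or the branching of tert-butyl matters more stays open; isopropyl or cyclohexyl on this carbon would help separate the two.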